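The source may hold more compounds than are shown below. What is called first, only, known or untested is meant among the compounds shown, and "the series" means these compounds.

Compounds measured in a functional assay on SGC-7901 cells (Homo sapiens) for antiproliferative activity, read by MTT assay, with a stated time of 24 h; on this read-out higher numbers stand for weaker inhibition and lower numbers for stronger inhibition:
compound 1 `Cc1ccc(-n2cc(-c3cccc(NS(=O)(=O)c4c[nH]c(=O)[nH]c4=O)c3)nn2)cc1` gives 9430 nM;
compound 2 `O=c1[nH]cc(S(=O)(=O)Nc2cccc(-c3cn(-c4ccccc4F)nn3)c2)c(=O)[nH]1` gives 16000 nM;
compound 3 `O=c1[nH]cc(S(=O)(=O)Nc2cccc(-c3cn(-c4ccc(F)cc4)nn3)c2)c(=O)[nH]1` gives > 20000 nM.

The figure for compound 3 is a limit of the assay the limit of > 20000 nM in this assay, at which 1 of the 3 values shown sits, and not a number, so compound 3 stands at the weak edge of what this assay can report. Both measured steps ending there point that way: an at least 2.1-fold higher number from compound 1 to compound 3 (0.32 log units; beyond the scatter), while an at least 1.2-fold higher number from compound 2 to compound 3 (0.09 log units; that floor lies within the scatter). Compound 4 `O=c1[nH]cc(S(=O)(=O)Nc2cccc(-c3cn(-c4ccc(Cl)cc4)nn3)c2)c(=O)[nH]1` differs from compound 3 by chloro in place of fluoro on an aromatic carbon. Among the measured compounds shown here, no measured step exchanges chloro for anything, so the only guide is that compound 3 already sits at the limit. Compound 4 is expected to stay near that edge, with an expected step of a number no higher from compound 3 to compound 4 (the limit leaves the size open). Compound 4 is estimated at 20000 nM, with a range from 8000 nM to 50000 nM.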

Compound 4, half-maximal inhibitory concentration: 2160 nM
Compound 4: middle estimate off by 9.3-fold (0.97 log units), on the high side; the whole stated range lies above it.
By their numbers in this assay, from the lowest: compound 4; then compounds 1 and 2 (each within the scatter of the next). At a limit, above all of these: compound 3.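

Chloro in place of fluoro on this aromatic carbon, para to a large group, gives an at least 9.2-fold lower number from compound 3 to compound 4 (0.96 log units; beyond the scatter) and so turns an inactive-looking compound into the most active one shown. Chloro also outdoes the earlier groups, with a 4.4-fold lower number from compound 1 to compound 4 (0.64 log units; beyond the scatter) and a 7.4-fold lower number from compound 2 to compound 4 (0.87 log units; beyond the scatter). The figure for compound 3 is a limit, so the first step gives only a floor: the limit of > 20000 nM in this assay, at which 1 of the 4 values shown sits.

On these data alone, whether bromo, methoxy or trifluoromethyl on the same carbon would lower the number further stays open. So does the effect of an amine there.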